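Swapping a Pyrazole for a Furan on the Shared Core

This account rests on a few compounds, and the source may have more. Where it says the series, first, only, none or still open, it means among the compounds named here.

Of the compounds shown here, three built on one shared core have been tested in a functional assay for antagonist activity at Neuropeptides B/W receptor type 1 (Homo sapiens), read by cAMP accumulation; on this read-out lower numbers stand for stronger inhibition and higher numbers for weaker inhibition. Compound 1 `FC(F)(F)c1ccc2[nH]c(-c3ccccc3)nc2c1` carries only hydrogen at the position of interest and gives 1200 nM. Compound 2 `FC(F)(F)c1ccc2[nH]c(-c3ccc(-c4nnc[nH]4)cc3)nc2c1` adds a 4H-1,2,4-triazol-3-yl group there and gives 3080 nM, which is a 2.6-fold higher number from compound 1 to compound 2 (0.41 log units; beyond the scatter). Compound 3 `Cn1cc(-c2ccc(-c3nc4cc(C(F)(F)F)ccc4[nH]3)cc2)cn1` carries a 1-methyl-1H-pyrazol-4-yl group instead and gives 1470 nM; this is a 1.2-fold higher number from compound 1 to compound 3 (0.09 log units; within the scatter), and a 2.1-fold lower number from compound 2 to compound 3 (0.32 log units; beyond the scatter). Compound 3 therefore stands second highest of the three numbers, close to compound 1 and apart from compound 2.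

Compound 4 `FC(F)(F)c1ccc2[nH]c(-c3ccc(-c4ccoc4)cc3)nc2c1` is the next step. The change is furan-3-yl in place of 1-methyl-1H-pyrazol-4-yl on an aromatic carbon. The two measured steps that bear on it are the additions of five-membered rings to compound 1: the triazolyl ring pushed the number up beyond the scatter, while the methylpyrazolyl ring left it within the scatter. A five-membered ring with a single hetero atom has no direct precedent among these compounds, so the expectation is that compound 4 lands near compound 3. Compound 4 is therefore expected to show a 1.1-fold lower number from compound 3 to compound 4 (0.05 log units; within the scatter). In this assay compound 4 is expected to give 1300 nM. The expected range for compound 4 runs from 500 nM to 3500 nM.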

Compound 4, half-maximal inhibitory concentration: 1190 nM
The estimate for compound 4 lay 1.1-fold (0.04 log units) above the measured number; the range from low to high includes it.
By their numbers in this assay, from the lowest: compounds 4, 1 and 3 (each within the scatter of the next); then compound 2.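

The step of a 1.0-fold lower number from compound 1 to compound 4 (0.00 log units; within the scatter) shows that furan-3-yl, like 1-methyl-1H-pyrazol-4-yl, can sit on this aromatic carbon, para to a large group, without moving the number beyond the scatter. Exchanging these two rings directly gives a 1.2-fold lower number from compound 3 to compound 4 (0.09 log units; within the scatter) and so also stays within the scatter, even though the entering ring has 1 hetero atom and 1 hydrogen-bond acceptor where the leaving ring has 2 of each. Among the rings shown, only 4H-1,2,4-triazol-3-yl stands apart, as a 2.6-fold lower number from compound 2 to compound 4 (0.41 log units; beyond the scatter) confirms from the furan side, and nothing available here explains what sets that ring apart.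

Going by these compounds, none of the three rings gives a number lower than that of compound 1 by more than the scatter, so it remains open whether any group on this carbon can strengthen inhibition. A carboxylic acid, a primary amine or a longer alkyl chain in place of these rings would test whether the number can move in that direction, and how far the tolerance seen for furan-3-yl and 1-methyl-1H-pyrazol-4-yl extends.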